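Swapping an Aminophenyl for an Aminopyridinyl Group

The source may report more compounds than this note shows. Statements on the series, on what has been measured and on what is new or still open speak of the compounds shown alone.

Compound 1 `Cc1ncc([N+](=O)[O-])n1CCSc1nnc(-c2ccc(N)cc2)o1` was tested in a functional assay on MCF7 cells (Homo sapiens) for cytotoxicity, read by MTT assay, with a stated time of 48 h (on this read-out higher numbers stand for weaker inhibition and lower numbers for stronger inhibition), and compound 1 gave 19800 nM. Compound 2 `COc1cc(-c2nnc(SCCn3c([N+](=O)[O-])cnc3C)o2)cc(OC)c1OC` gave 30600 nM in the same this assay. Only these two numbers exist so far; the gap between compound 1 and compound 2 lies within the scatter of repeated measurements, so neither can be told apart from the other. Compound 3 `Cc1ncc([N+](=O)[O-])n1CCSc1nnc(-c2ccc(N)nc2)o1` has not yet been measured. It differs from compound 1 in one place: 6-aminopyridin-3-yl in place of 4-aminophenyl on an aromatic carbon. Among the measured compounds shown here, no pair of measured compounds shows what this change does, so there is no measured step to lean on. The expected step is about a 1.1-fold higher number from compound 1 to compound 3 (0.05 log units; within the scatter), which means little or no change beyond the scatter. Compound 3 is therefore estimated at 22000 nM, with a range from 8000 nM to 60000 nM.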

Compound 3, half-maximal inhibitory concentration: 26800 nM
Estimate against measurement, compound 3: 1.2-fold (0.09 log units) below; low and high end bracket the measured number.
By their numbers in this assay, from the lowest: compounds 1, 3 and 2 (each within the scatter of the next).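

Among the compounds shown here, this is the first step at this position, the aromatic carbon of the five-membered ring, that can be read: in this assay the exchange of 4-aminophenyl for 6-aminopyridin-3-yl gives a 1.4-fold higher number from compound 1 to compound 3 (0.13 log units; within the scatter) and so cannot be told apart from no change. In this one pair, a ring nitrogen and the extra hydrogen-bond acceptor counted with it enter the six-membered aromatic ring without a shift that rises above the scatter of this cell read-out. Nothing measured here bears on the reason for this result.

Going by these compounds, what the amine on the six-membered ring contributes stays open, as compound 1 and compound 3 both carry it. A hydroxyl group or a carboxylic acid in its place would speak to that question.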